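A 4-fluorobenzyl group on the amide nitrogen

This account rests on a few compounds, and the source may have more. Where it says the series, first, only, none or still open, it means among the compounds named here.

In a functional assay on HeLa cells (Homo sapiens) for inhibition, read by MTT assay, with a stated time of 48 h (on this read-out lower numbers stand for stronger inhibition and higher numbers for weaker inhibition), compound 2 `COc1cccc(NC(=O)/C=C/c2coc3cc(OC)ccc3c2=O)c1` gives 19200 nM and compound 1 `COc1ccc2c(=O)c(/C=C/C(=O)NCc3ccccc3)coc2c1` gives 33400 nM, so these two values lie within the scatter of each other. Compound 3 `COc1ccc2c(=O)c(/C=C/C(=O)NCc3ccc(F)cc3)coc2c1` has 4-fluorobenzyl in place of 3-methoxyphenyl on an amide-type nitrogen. Going by the values given here, the only measured step at this nitrogen is a 1.7-fold lower number from compound 1 to compound 2 (0.24 log units; within the scatter), a swap of benzyl for 3-methoxyphenyl that stays within the scatter. Among the compounds with values here, no measured step shows the effect of adding fluorine. No change beyond the scatter is therefore expected in this assay. The expected size is a 1.4-fold higher number from compound 2 to compound 3 (0.15 log units; within the scatter). The estimate for compound 3 is 27000 nM, with a range of 13000 nM to 55000 nM.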

Compound 3, half-maximal inhibitory concentration: > 100000 nM
Compound 3 was reported as a limit (the forecaster's own chance of this, stated with the estimate: 5%); at least 3.7-fold (0.56 log units) between middle value and limit.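

In this assay compound 3 is reported as a limit, not a number: the limit of > 100000 nM in this assay, at which 1 of the 3 values shown sits. Even so, the group on this amide-type nitrogen now matters in a way the earlier pair did not show, with an at least 5.2-fold higher number from compound 2 to compound 3 (0.71 log units; beyond the scatter) and an at least 2.9-fold higher number from compound 1 to compound 3 (0.47 log units; beyond the scatter). The second step is only fluoro in place of hydrogen on an aromatic carbon, so a single-atom change on the benzyl group is enough to weaken inhibition.

Going by these compounds, how far inhibition really falls stays unknown. On these data alone, whether this loss is particular to fluoro also stays open, and a chlorine atom or an amine on that same aromatic carbon would test it.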